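The source may report more compounds than this note shows. Statements on the series, on what has been measured and on what is new or still open speak of the compounds shown alone.

The measured compounds:

Compound 1, `COc1cc(C(c2ccc(O)c(OC)c2)[C@H](C)[C@H](C)CO)ccc1O`, reaches only the limit of a functional assay on HL-60 cells (Homo sapiens) for cytotoxicity, read by WST assay, with a stated time of 48 h (a higher number here means a weaker inhibitor, a lower number a stronger inhibitor), giving > 100000 nM.
Compound 2, `COc1cc(C(c2ccc(O)c(OC)c2)[C@@H](CF)C(C)C)ccc1O`, gives 39000 nM in this assay.
Compound 3, `CCCCCCCC[C@H](C(C)C)C(c1ccc(O)c(OC)c1)c1ccc(O)c(OC)c1`, gives 3700 nM in this assay.

Compound 3 stands at the lowest of the two numbers in this assay, below compound 2, while compound 1 sits at the limit (the limit of > 100000 nM in this assay, at which 1 of the 3 values shown sits) and so supplies no number. Among the measured pairs, only one step is a single change: an at least 2.5-fold lower number from compound 1 to compound 2 (0.40 log units; beyond the scatter), where compound 1 stops at a limit, so the step is a minimum, not an exact size.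

Compound 4, `COc1cc(C(c2ccc(O)c(OC)c2)[C@H](CF)C(C)C)ccc1O`, has not yet been measured in this assay. It differs from compound 3 in one place: fluoro in place of heptyl on a saturated chain carbon, three bonds along the chain from two aromatic carbons. For the measured compounds named here, no measured step in this set swaps a long chain for a fluoro, so the single step seen carries little direct weight here. What the numbers do show is that compound 2, which carries a fluoromethyl group in place of a long chain, sits well above compound 3. Compound 4 is therefore expected to give a higher number than compound 3, estimated as an 8.1-fold higher number from compound 3 to compound 4 (0.91 log units; beyond the scatter), with compound 4 landing near 30000 nM, somewhere between 8000 nM and 150000 nM.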

Compound 4, half-maximal inhibitory concentration: 19000 nM
Beside the measured number, compound 4's estimate is 1.6-fold (0.20 log units) above it; the range from low to high includes it.
By their numbers in this assay, from the lowest: compound 3; then compound 4; then compound 2. At a limit, above all of these: compound 1.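

Compounds 2 and 4 share the same atoms and bonds, yet in this assay the change of drawn configuration alone gives a 2.1-fold lower number from compound 2 to compound 4 (0.31 log units; beyond the scatter), so this stereocentre has a measurable effect on cytotoxicity, which the earlier compounds could not show: the fact that compounds 2 and 4 differ only in the configuration as drawn

For the compounds shown here, the new compound also gives the first single-place comparison of the long chain with the small fluoro ending, a 5.1-fold higher number from compound 3 to compound 4 (0.71 log units; beyond the scatter), and in this pair the heptyl-bearing compound has the lower number, meaning the stronger inhibition of cell growth. Changing the whole side chain from 2-(hydroxymethyl)-1-methylpropyl to 1-(fluoromethyl)-2-methylpropyl gives an at least 5.2-fold lower number from compound 1 to compound 4 (0.72 log units; beyond the scatter), which is only a minimum, as one end of this step is a limit: the limit of > 100000 nM in this assay, at which 1 of the 4 values shown sits.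

The compounds shown leave open how the number changes with chains of intermediate length, such as butyl, or with an aminomethyl group at this position. They also leave open whether configuration matters as much with the octyl chain as it does with fluoromethyl, and they do not explain why either change moves the number.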